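Formyl for cyano on the core of compound 3

A few compounds are considered here, and "the series" means these few. Any claim that something is new, unique, unknown or untested is made for them only; others in the source may bear on it.

Compound 3, `N#Cc1cccc2c(CN3CCN(c4ccc(Cl)cc4)CC3)cnn12`, gives 1.5 nM in an assay on CHO cells for binding affinity to D(4) dopamine receptor (Homo sapiens); a lower number here means a stronger inhibitor, a higher number a weaker inhibitor. Among the three measured compounds it stands second highest: nearest is compound 1, `C#Cc1cccc2c(CN3CCN(c4ccc(Cl)cc4)CC3)cnn12`, with 1.2 nM, a gap within the scatter, while compound 2, `Clc1ccc(N2CCN(Cc3cnn4c(-c5ccccc5)cccc34)CC2)cc1`, with 7.6 nM, lies furthest, a step of a 5.1-fold lower number from compound 2 to compound 3 (0.70 log units; beyond the scatter). Compound 4, `O=Cc1cccc2c(CN3CCN(c4ccc(Cl)cc4)CC3)cnn12`, differs from compound 3 by formyl in place of cyano on an aromatic carbon. The step of a 1.3-fold higher number from compound 1 to compound 3 (0.10 log units; within the scatter) shows that swapping one two-heavy-atom group for another at this carbon left the number within the scatter, whereas only the larger phenyl in compound 2 shifted it. Formyl being a two-heavy-atom group, compound 4 is expected to stay close to compound 3, an estimated step of a 1.3-fold higher number from compound 3 to compound 4 (0.12 log units; within the scatter). Compound 4 is therefore estimated at 2 nM, between 0.7 nM and 6 nM.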

Compound 4, inhibition constant: 2.6 nM
Beside the measured number, compound 4's estimate is 1.3-fold (0.11 log units) below it; measured number inside the range.
By their numbers in this assay, from the lowest: compounds 1, 3 and 4 (each within the scatter of the next, the first and the last beyond it); then compound 2.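

Formyl stays within the scatter of nitrile at this carbon (a 1.7-fold higher number from compound 3 to compound 4 (0.24 log units; within the scatter)). Against ethynyl, however, it gives the first step between two-heavy-atom groups here that lies beyond the scatter (a 2.2-fold higher number from compound 1 to compound 4 (0.34 log units; beyond the scatter)), although compound 3 lies within the scatter of both compound 1 and compound 4. Formyl also remains clearly apart from phenyl (a 2.9-fold lower number from compound 2 to compound 4 (0.47 log units; beyond the scatter)).

On these data alone, whether an amine, a carboxylic acid or a longer chain at this carbon would stay near these values remains open. The data shown offer no explanation for any of these steps.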